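Trifluoromethyl Step Repeated on a Second Core

The compounds below may be only part of what the source reports. "The series", "measured", "known", "first", "only" and "open" are said of these compounds alone.

Compound 1 `Cc1ccc(S(=O)(=O)Oc2ccc3c(c2C)[C@H](Cn2cc(-c4ccccc4)nn2)[C@@]24CC(=O)[C@@](C)(CC[C@@H]32)C4)cc1` and compound 2 `Cc1ccc(S(=O)(=O)Oc2ccc3c(c2C)[C@H](Cn2cc(-c4ccc(C(F)(F)F)cc4)nn2)[C@@]24CC(=O)[C@@](C)(CC[C@@H]32)C4)cc1` share one core, while compound 3 `C=C1C[C@]23C[C@@]1(O)CC[C@H]2c1ccc(OS(=O)(=O)c2ccc(C)cc2)c(C)c1[C@@H]3Cn1cc(-c2ccccc2)nn1` and compound 4 `C=C1C[C@]23C[C@@]1(O)CC[C@H]2c1ccc(OS(=O)(=O)c2ccc(C)cc2)c(C)c1[C@@H]3Cn1cc(-c2ccc(C(F)(F)F)cc2)nn1` share another. The difference between the two cores is not broken down here. In a functional assay on MCF7 cells (Homo sapiens) for cytotoxicity, read by MTT assay, with a stated time of 4 days (a lower number here means a stronger inhibitor, a higher number a weaker inhibitor), compound 1 reaches only the limit of the assay, > 20000 nM. Compound 2 likewise reaches only the limit, > 20000 nM. The change from compound 1 to compound 2 is trifluoromethyl in place of hydrogen on an aromatic carbon, and it gives a step that the two limits leave unreadable from compound 1 to compound 2. Compound 3 also reaches only the limit in this assay, > 20000 nM. Compound 4 carries the same change on its own core, (trifluoromethyl in place of hydrogen on an aromatic carbon), with the place described in the same words for both pairs. Within the data shown here, because of the limit of > 20000 nM in this assay, at which 3 of the 3 values shown sit, no measured step is available that would place compound 4 elsewhere. Compound 4 is therefore expected to give 30000 nM in this assay, most probably reported again only as a limit. The estimated step that the limit leaves unreadable from compound 3 to compound 4 rests on the fact that (the limit of > 20000 nM in this assay, at which 3 of the 3 values shown sit), so no movement is expected.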

Compound 4, half-maximal inhibitory concentration: > 20000 nM
Compound 4: only a limit was reported; the forecaster's own chance of this, stated with the estimate: 85%; the middle value does not contradict the limit.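

In this assay compound 3 and compound 4 are both reported only as a limit, so no step can be read for the trifluoromethyl change on their core. The compounds shown leave open what value any of them has, and whether this change moves that value on either core: the limit of > 20000 nM in this assay, at which 4 of the 4 values shown sit.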